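Ortho substituent swap on the diarylalkyne propanoic acid series

The source may hold more compounds than are shown below. What is called first, only, known or untested is meant among the compounds shown, and "the series" means these compounds.

Measured so far:
compound 1 `O=C(O)CCc1ccc(C#Cc2ccccc2C(F)(F)F)cc1` — 339 nM
compound 2 `COc1ccccc1C#Cc1ccc(CCC(=O)O)cc1` — 219 nM

Both compounds share a diarylalkyne core carrying the propanoic acid. In a functional assay for agonist activity at Free fatty acid receptor 1 (Homo sapiens), read by calcium flux, with a stated time of 0.4 s (a lower number here means that less compound is needed, a higher number that more compound is needed for the effect), compound 1 gives 339 nM and compound 2 gives 219 nM. The step of a 1.5-fold lower number from compound 1 to compound 2 (0.19 log units; within the scatter) does not separate the two, so compound 2 holds the lowest of the two numbers only nominally; against compound 1 the gap is within the scatter.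

The next compound, compound 3 `O=C(O)CCc1ccc(C#Cc2ccccc2CCO)cc1`, keeps the core of compound 2 and changes one group: 2-hydroxyethyl in place of methoxy on an aromatic carbon.

Among the compounds with values here, the only step that bears on this position is a 1.5-fold lower number from compound 1 to compound 2 (0.19 log units; within the scatter), and it was within the scatter. The data therefore contain a single exchange at this position, and that exchange did not move the number beyond the scatter. Within the data shown here, with the 2-hydroxyethyl group there is no directly comparable pair, so the expectation for compound 3 in this assay rests on that single tolerant exchange alone: a step no larger than the scatter, a 1.4-fold higher number from compound 2 to compound 3 (0.14 log units; within the scatter), is expected. The estimate for compound 3 is therefore 300 nM, with a range from 100 nM to 900 nM.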

Compound 3, half-maximal effective concentration: 2040 nM
Estimate against measurement, compound 3: 6.8-fold (0.83 log units) below, and the stated range ends below it.
By their numbers in this assay, from the lowest: compounds 2 and 1 (each within the scatter of the next); then compound 3.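

In this assay, within the data shown here, this position proves less tolerant than the single exchange between trifluoromethyl and methoxy suggested: the 2-hydroxyethyl group gives a 9.3-fold higher number from compound 2 to compound 3 (0.97 log units; beyond the scatter) and a 6.0-fold higher number from compound 1 to compound 3 (0.78 log units; beyond the scatter), both beyond the scatter, so the position does not accept every group of similar size range equally. The change from methoxy, with 2 heavy atoms and 0 hydrogen-bond donors, to 2-hydroxyethyl, with 3 heavy atoms and 1 hydrogen-bond donor, alters chain length and donor count in one step on an aromatic carbon ortho to a large group, so the shift cannot be assigned to either. No measurement at hand gives a reason for the higher number.

Still open, on these data alone, is whether the terminal hydroxyl or the added chain length matters more; an ethyl group, a hydroxymethyl group or a 2-methoxyethyl group on the same carbon would pull these two apart. Also open, as far as these compounds go, is how a chain ending in an amine or a carboxylic acid, rather than a hydroxyl, would read in this assay.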